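Amide ester to methylamide in a weakly active triazole series

The source may report more compounds than this note shows. Statements on the series, on what has been measured and on what is new or still open speak of the compounds shown alone.

Compound 1 `CCn1c(CNc2ccccc2)nnc1SCC(=O)Nc1ccccc1` carries a plain phenyl amide on the shared core. In an assay on isolated protein for inhibition of long-chain fatty acid transport protein 1 (Mus musculus) (a higher number here means a weaker inhibitor, a lower number a stronger inhibitor), compound 1 gives > 10000 nM, which is a limit of the assay rather than a number. Compound 2 `CCn1c(CNc2ccccc2)nnc1SCC(=O)Nc1ccc(Cl)cc1` differs by chloro in place of hydrogen on an aromatic carbon. In this assay compound 2 gives > 10000 nM, again a limit. The step that the two limits leave unreadable from compound 1 to compound 2 is therefore unreadable in size. Compound 3 `CCn1c(CNc2ccccc2)nnc1SCC(=O)Nc1ccc(C(=O)OC)cc1` bears a methoxycarbonyl group on the amide phenyl ring. In this assay compound 3 shows "not determined" (no result reported), so no number places it among the others. Compound 4 `CCn1c(CNc2ccccc2)nnc1SCC(=O)Nc1ccc(C(=O)NC)cc1` is reached from compound 3 by methylamino in place of methoxy on a carbonyl carbon. For the measured compounds named here, no measured step bears on this change; the only guide is the limit of > 10000 nM in this assay, at which 2 of the 3 values shown sit, and the series so far offers no value that is more than a limit. One therefore expects compound 4 to land near that same limit, most likely again without a readable number. In this assay compound 4 is estimated at 15000 nM, with a range from 3000 nM to 60000 nM.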

Compound 4, half-maximal inhibitory concentration: > 10000 nM
Compound 4 gave a limit, no number; the forecaster's own chance of this, stated with the estimate: 80%; the middle value lies beyond the limit too.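

In this assay compound 4 gives > 10000 nM, a limit and not a number. No step from compound 1 or compound 2 to compound 4 can be read, since all three values are limits: the limit of > 10000 nM in this assay, at which 3 of the 4 values shown sit.

The compounds shown leave open whether any group on the amide phenyl ring gives a readable value.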